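Four Methyl Groups Added to a Hydroxypiperidine Ring

The source may report more compounds than this note shows. Statements on the series, on what has been measured and on what is new or still open speak of the compounds shown alone.

Three measured compounds share one core and differ only in the amine-bearing chain attached to an oxygen on the aromatic ring. In an ADME assay on microsomes from liver (Homo sapiens) for metabolic stability, read by LC-MS, tested at 1 uM (a higher number here means faster removal of the compound, a lower number slower removal), compound 3 `OC1(COc2ccc([C@H]3CC[C@]4(CC3)OOC3(O4)C4CC5CC(C4)CC3C5)cc2)CCNCC1` gives 16 mL.min-1.g-1, the only result here reported as a number. Compound 1 `c1cc([C@H]2CC[C@]3(CC2)OOC2(O3)C3CC4CC(C3)CC2C4)ccc1OCCC1CCNCC1` gives < 7 mL.min-1.g-1, which is a limit of the assay and not a number. Compound 2 `CC(C)(CN)Oc1ccc([C@H]2CC[C@]3(CC2)OOC2(O3)C3CC4CC(C3)CC2C4)cc1` gives < 7 mL.min-1.g-1, again a limit. Compound 3 therefore stands apart from the limit of < 7 mL.min-1.g-1 in this assay, at which 2 of the 3 values shown sit, and both steps toward it point the same way: an at least 2.2-fold higher number from compound 1 to compound 3 (0.35 log units; beyond the scatter), and an at least 2.2-fold higher number from compound 2 to compound 3 (0.35 log units; beyond the scatter).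

Compound 4 `CC1(C)CC(O)(COc2ccc([C@H]3CC[C@]4(CC3)OOC3(O4)C4CC5CC(C4)CC3C5)cc2)CC(C)(C)N1` keeps the hydroxypiperidine of compound 3 and changes it as follows: 4-hydroxy-2,2,6,6-tetramethylpiperidin-4-yl in place of 4-hydroxypiperidin-4-yl on a saturated chain carbon bound to an oxygen on an aromatic ring. Neither measured step resembles this change; both exchange one amine-bearing chain for a different one, whereas here the same ring is kept and carbon is added to it. Among the measured compounds shown here, with no step of that kind to lean on, the expected outcome is a step of a 1.3-fold higher number from compound 3 to compound 4 (0.10 log units; within the scatter), that is, a number close to that of compound 3 and not clearly beyond the scatter. Compound 4 is thus estimated at 20 mL.min-1.g-1 in this assay, with a likely range from 8 mL.min-1.g-1 to 50 mL.min-1.g-1.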

Compound 4, intrinsic clearance in microsomes: 14 mL.min-1.g-1
Compound 4: the middle estimate sits 1.4-fold (0.15 log units) above what was measured; the measured number falls inside the stated range.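

Among the compounds shown here, this is the first step that keeps the hydroxypiperidine ring and only adds carbon to it. In this assay, 4-hydroxy-2,2,6,6-tetramethylpiperidin-4-yl in place of 4-hydroxypiperidin-4-yl on a saturated chain carbon bound to an oxygen on an aromatic ring gives a 1.1-fold lower number from compound 3 to compound 4 (0.06 log units; within the scatter), so the four added methyl groups leave the two compounds indistinguishable in this measurement. The steps from the other two chains read an at least 2.0-fold higher number from compound 2 to compound 4 (0.30 log units; that floor lies within the scatter) and an at least 2.0-fold higher number from compound 1 to compound 4 (0.30 log units; that floor lies within the scatter), floors that on their own do not clear the scatter, while compound 4 gives 14 mL.min-1.g-1, which sets it apart from one reference point: the limit of < 7 mL.min-1.g-1 in this assay, at which 2 of the 4 values shown sit.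

The compounds shown leave open how the same ring would read with two methyl groups instead of four, with a tertiary amine in the ring, or with a fluorine in place of the hydroxyl group. Also open, going by these compounds, is whether the four methyl groups would give a similar reading on the piperidine ring of compound 1, whose own result is only a limit.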